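The source may hold more compounds than are shown below. What is called first, only, known or untested is meant among the compounds shown, and "the series" means these compounds.

Of the compounds shown here, three built on a shared core have been tested so far in a functional assay on HCT-15 cells (Homo sapiens) for inhibition, read by sulforhodamine B assay, with a stated time of 48 h, tested at 10 uM; a lower number here means less inhibition of growth, a higher number more inhibition of growth at the concentration tested. Compound 1 `COc1ccc(-c2nc3sc(-c4ccccc4)cn3n2)cc1` gives 69%, and compound 2 `COc1cc(-c2nc3sc(-c4ccccc4)cn3n2)cc(OC)c1OC` gives 42%. Compound 3 `Clc1ccc(-c2cn3nc(-c4ccccc4)nc3s2)cc1` gives only 9%, the lowest of the three numbers. Compound 2, its nearest neighbour on this scale, still lies well above it, by more than repeat measurements would normally scatter, and compound 1 lies further above still.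

The next compound to be measured is compound 4 `COc1ccc(-c2nc3sc(-c4ccc(Cl)cc4)cn3n2)cc1`. It is made from compound 3 by placing methoxy in place of hydrogen on an aromatic carbon, on a six-membered aromatic ring of carbon only, para to a large group (methoxy in place of hydrogen on an aromatic carbon).

Among the compounds with values here, no measured pair in this small set shows a single change of this kind, so any forecast is uncertain. Within the data shown here, the only guide is that compound 1, which also carries a methoxy group, reaches 69% in this assay. A clear rise in growth inhibition, beyond the scatter, is therefore expected, and the estimated change is a number 36 percentage points higher from compound 3 to compound 4 (beyond the scatter). With so little data, the expected range is wide. For compound 4 the estimated value is 45%, expected to fall between 15% and 78%.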

Compound 4, percent growth inhibition at one concentration: 28%
For compound 4 the middle estimate is 17 percentage points above the measured one, within the range that was stated.
By their numbers in this assay, from the lowest: compound 3; then compound 4; then compound 2; then compound 1.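

Methoxy at this place does raise growth inhibition in this assay when the rest of the molecule is held fixed, a single change that the earlier compounds could not isolate: a number 19 percentage points higher from compound 3 to compound 4 (beyond the scatter) is a real but modest gain. The chloro group, which the new compound carries along with the methoxy, matters more, since the step of a number 41 percentage points lower from compound 1 to compound 4 (beyond the scatter) is large and leaves the methoxy compound well short of where it stood without chloro. Methoxy therefore does not guarantee strong growth inhibition on its own, and the outcome depends on what else the molecule carries, though nothing measured here explains why.

Within the data shown here, the methoxy step has been seen only with chloro present, so its size in a compound without chloro remains open, as does whether fluoro or methyl in place of chloro would cost as much. It is also unknown whether a hydroxyl group, an amine or a longer chain such as ethoxy, on the same aromatic carbon para to a large group, would give more growth inhibition than methoxy does.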